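Adding a methyl to compound 3: what to expect

This account rests on a few compounds, and the source may have more. Where it says the series, first, only, none or still open, it means among the compounds named here.

Compound 1, `Cc1cc(C)nc(Oc2ccc(NC(=O)Nc3ccc(Cl)cc3)cc2)n1`: in a functional assay on MCF7 cells (Homo sapiens) for cytotoxicity, read by MTT assay, with a stated time of 3 days (on this read-out higher numbers stand for weaker inhibition and lower numbers for stronger inhibition), compound 1 gives > 50000 nM, a limit of the assay.
Compound 2, `Cc1cc(C)nc(Oc2ccc(NC(=O)Nc3ccc(Cl)cc3Cl)cc2)n1`: in this assay compound 2 gives 47800 nM.
Compound 3, `Cc1cc(C)nc(Sc2ccc(NC(=O)Nc3ccccc3)cc2)n1`: in this assay compound 3 gives > 50000 nM, a limit of the assay.

Compound 3 therefore stands not at a number but at the limit of > 50000 nM in this assay, at which 2 of the 3 values shown sit, so its cytotoxicity toward these cells is known only as weaker than that limit. Compound 4, `Cc1cccc(NC(=O)Nc2ccc(Sc3nc(C)cc(C)n3)cc2)c1`, differs from it in one place: methyl in place of hydrogen on an aromatic carbon, a methyl in place of hydrogen on an aromatic carbon, meta to a large group.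

For the measured compounds named here, only one measured step bears on such a change. Between compound 1 and compound 2 a chloro also replaced a hydrogen on an aromatic carbon of the same ring, and that step, an at least 1.0-fold lower number from compound 1 to compound 2 (0.01 log units; that floor lies within the scatter), stayed within the scatter, with the pair moving from a limit to a number close to it. A small substituent on that ring thus left this assay essentially unchanged.

On this basis no step beyond the scatter is expected from compound 3 to compound 4, an estimated a number no higher from compound 3 to compound 4 (the limit leaves the size open), and the assay may again report only a limit. Compound 4 is expected to give about 50000 nM, between 25000 nM and 100000 nM.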

Compound 4, half-maximal inhibitory concentration: 37000 nM
Compound 4: middle estimate off by 1.4-fold (0.13 log units), on the high side, and the stated range covers the measured number.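

In this assay compound 4 gives 37000 nM, so a methyl on an aromatic carbon, meta to a large group, yields a number. The unsubstituted compound 3 gave only a limit. This adds a second small group to the chloro seen earlier and tests a new place on the ring, and the result is the same in kind, as the step, an at least 1.3-fold lower number from compound 3 to compound 4 (0.13 log units; that floor lies within the scatter), shows no change beyond the scatter while leaving a larger one possible. The true size of the step cannot be read, since the value of compound 3 is a limit of the assay: the limit of > 50000 nM in this assay, at which 2 of the 4 values shown sit.

The compounds shown leave open whether a different group on this same aromatic carbon, such as an amine, a methoxy group, a carboxylic acid or a longer chain, would move the number clearly beyond the scatter in this assay. They also leave open whether the same methyl would act alike on the core of compound 1, which carries an oxygen where compound 3 carries a sulfur.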